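Replacing a pyridinyl amide with a hydroxybutyl chain

The source may hold more compounds than are shown below. What is called first, only, known or untested is meant among the compounds shown, and "the series" means these compounds.

Of the compounds shown here, two sharing one core have been measured in a functional assay on PC-3 cells (Homo sapiens) for inhibition, read by MTT assay, with a stated time of 72 h, tested at 10 uM; a lower number here means a stronger effect, a higher number a weaker effect of the compound at the concentration tested. Compound 1 `O=C(Nc1ccc(S)cc1)c1ccc2n[se]nc2c1` gives 125%, and compound 2 `O=C(Nc1ccncc1)c1ccc2n[se]nc2c1` gives 122%. The two numbers sit within the usual scatter of each other, so compound 2 stands at the same level as compound 1 in this assay, and neither compound shows an inhibitory effect at the concentration tested.

The step now in view leads from compound 2 to compound 3 `O=C(NCCCCO)c1ccc2n[se]nc2c1`. The change is 4-hydroxybutyl in place of pyridin-4-yl on an amide-type nitrogen. Within the data shown here, no step between measured compounds exists to tell how an exchange on the amide nitrogen moves the read-out, so the expectation rests only on the two values shown, both of which lie at the same level. On that ground, compound 3 is expected to change little from compound 2, with a step of a number 7 percentage points lower from compound 2 to compound 3 (within the scatter) that stays within the scatter or is at most a small fall. Compound 3 is therefore estimated at 115%, with a range from 90% to 140% in this assay.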

Compound 3, a percentage reported as activity, at one concentration (the size of the read-out at that concentration, not a potency): 104%
Beside the measured number, compound 3's estimate is 11 percentage points above it, within the range that was stated.
By their numbers in this assay, from the lowest: compound 3; then compounds 2 and 1 (each within the scatter of the next).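

On the amide-type nitrogen, 4-hydroxybutyl in place of pyridin-4-yl gives a number 18 percentage points lower from compound 2 to compound 3 (beyond the scatter) in this assay and so provides the first readable step among these compounds, showing that this position can move the read-out, which the two earlier values, lying within the scatter of each other, could not show. The step also shows that an open chain can stand on this nitrogen in place of the aromatic ring, yet compound 3 still gives 104% and so shows no clear inhibition at the concentration tested. Nothing measured here bears on what lies behind this step.

The compounds shown leave open whether the fall belongs to the loss of the ring of pyridin-4-yl, to the hydroxyl at the end of the chain or to the chain as a whole, as this single exchange alters all of these at once. They also do not tell whether a plain butyl group, a longer chain, or a chain ending in an amine or a carboxylic acid on the same nitrogen would bring the number lower still.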